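This account rests on a few compounds, and the source may have more. Where it says the series, first, only, none or still open, it means among the compounds named here.

Measured so far in an ADME assay on MCF-10A cells (Homo sapiens) for cytotoxicity, read by MTT assay, with a stated time of 72 h; on this read-out lower numbers stand for stronger inhibition of growth and higher numbers for weaker inhibition of growth: compound 1 `CS/C(=N\C(=O)c1cc2ccccc2s1)NC(=O)c1cc2ccccc2s1` gives 20 nM. Compound 3 `CS/C(=N\C(=O)c1cccs1)NC(=O)c1cccs1` gives 19700 nM. Compound 2 `O=C(/N=C(/NC(=O)c1cccs1)[Se]Cc1ccccc1)c1cccs1` gives 72500 nM.

Compound 2 differs from compound 3 in one place: a group of 8 heavy atoms (7 carbon, 1 selenium; one six-membered aromatic ring of carbon only) in place of a group of 2 heavy atoms (1 carbon, 1 sulfur; no ring), on a carbon with a double bond to nitrogen. That change brought a 3.7-fold higher number from compound 3 to compound 2 (0.57 log units; beyond the scatter), so compound 2 inhibits growth less strongly than compound 3. Compound 4 `O=C(/N=C(/NC(=O)c1cc2ccccc2s1)[Se]Cc1ccccc1)c1cc2ccccc2s1` has not yet been measured. It differs from compound 1 by a group of 8 heavy atoms (7 carbon, 1 selenium; one six-membered aromatic ring of carbon only) in place of a group of 2 heavy atoms (1 carbon, 1 sulfur; no ring), on a carbon with a double bond to nitrogen, the same change made on a different core; the difference between the two cores is not broken down here. Compound 1 has the lowest number of the three measured and stands far from both others. Because of a 3.7-fold higher number from compound 3 to compound 2 (0.57 log units; beyond the scatter) a step of similar size is expected here, a 3.8-fold higher number from compound 1 to compound 4 (0.57 log units; beyond the scatter). Going by the values given here, only one example carries this change, so the expectation is uncertain. Compound 4 is therefore estimated at 75 nM in this assay, likely between 25 nM and 300 nM.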

Compound 4, concentration for 50% growth inhibition: 37900 nM
Compound 4: the middle estimate sits 510-fold (2.70 log units) below what was measured; the whole stated range lies below it.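

In this assay, putting the selenium group with its six-membered aromatic ring in place of methylsulfanyl gives a 1900-fold higher number from compound 1 to compound 4 (3.28 log units; beyond the scatter), so growth inhibition weakens on both cores, but the size of the step does not carry over: the same change on two cores in this assay, a 3.7-fold higher number (0.57 log units; beyond the scatter) from compound 3 to compound 2 and a 1900-fold higher number (3.28 log units; beyond the scatter) from compound 1 to compound 4, 510-fold (2.71 log units) apart, beyond the scatter of two such steps The direction held in these two pairs, while the step on one core proved a poor guide to its size on the other. Two pairs do not show why the steps differ, or which feature of the core of compound 1 goes with the larger one.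

Selenium and the aromatic ring enter together, so their separate contributions remain open. Also open, as far as these compounds go, is how a methyl group on selenium, a benzyl group on sulfur or an amine at this carbon would behave on either core.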